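The compounds below may be only part of what the source reports. "The series", "measured", "known", "first", "only" and "open" are said of these compounds alone.

Values in a functional assay on HT-29 cells (Homo sapiens) for inhibition, read by sulforhodamine B assay, with a stated time of 48 h; on this read-out lower numbers stand for stronger inhibition of growth and higher numbers for weaker inhibition of growth:
- Compound 1 `c1cc(OC2CCCCCC2)ccc1NC1=NCCO1`: 16600 nM
- Compound 2 `O=C(CCl)NC(=O)Nc1ccc(OC2CCCC2)cc1`: 3100 nM
- Compound 3 `O=C(CCl)NC(=O)Nc1ccc(OC2CCCCCC2)cc1`: 2300 nM

Compound 3 has the lowest number of the three, but compound 2 cannot be told apart from it, and only compound 1 clearly stands higher. Compound 4 `O=C(CCl)NC(=O)Nc1ccc(OCc2ccccc2)cc1` differs from compound 3 in one place: benzyl in place of cycloheptyl on an oxygen on an aromatic ring. The closest guide is the earlier change on that same oxygen, a 1.3-fold lower number from compound 2 to compound 3 (0.13 log units; within the scatter). The other step, a 7.2-fold lower number from compound 1 to compound 3 (0.86 log units; beyond the scatter), concerns a group on a nitrogen and says little here. The expected step is therefore small, a 1.2-fold higher number from compound 3 to compound 4 (0.09 log units; within the scatter), and none beyond the scatter. For compound 4 the estimated value is 2800 nM, with an expected range from 1200 nM to 6500 nM.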

Compound 4, concentration for 50% growth inhibition: 2600 nM
For compound 4 the middle estimate is 1.1-fold (0.03 log units) above the measured one; low and high end bracket the measured number.
By their numbers in this assay, from the lowest: compounds 3, 4 and 2 (each within the scatter of the next); then compound 1.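

In this assay, putting an aromatic ring on this oxygen in place of a non-aromatic one leaves the number practically unmoved, with a 1.1-fold higher number from compound 3 to compound 4 (0.05 log units; within the scatter) and a 1.2-fold lower number from compound 2 to compound 4 (0.08 log units; within the scatter). Cyclopentyl, cycloheptyl and benzyl on an oxygen on an aromatic ring therefore cannot be told apart here, so this position accepts all three ring groups without a readable change. Nothing measured here explains why they read alike. Still open, on these data alone, is how a short chain such as methyl on this oxygen would compare. So is whether an amine or a carboxylic acid on the benzyl ring would shift the number.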